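The source may hold more compounds than are shown below. What is called first, only, known or untested is meant among the compounds shown, and "the series" means these compounds.

Working notes on the series. Within the data shown here, in an ADME assay on HEK-293T cells (Homo sapiens) for cytotoxicity, read by CCK-8 assay, with a stated time of 48 h (a lower number here means a stronger inhibitor, a higher number a weaker inhibitor), compound 1 `O=S(=O)(NCCNC(=S)Nc1cccc(Cl)c1)c1ccc(-c2ccccc2OCc2cccc(O)c2)s1` gives 17400 nM, the only true number among the measured compounds. Compound 2 `COc1ccc(Oc2ccc([N+](=O)[O-])cc2-c2ccsc2S(=O)(=O)N2CCN(C(=S)Nc3ccc(Cl)cc3)CC2)cc1OC` reads > 50000 nM, which is a limit of the assay. Compound 3 `Nc1ccc(Oc2ccccc2-c2ccc(S(=O)(=O)NCCNC(=O)Nc3ccc(Cl)cc3)s2)cc1` reads > 20000 nM, which is also a limit. Neither limit gives a position relative to compound 1.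

Compound 4 `O=C(NCCNS(=O)(=O)c1ccc(-c2ccccc2OCc2cccc(O)c2)s1)Nc1cc(Cl)cc(Cl)c1` is still to be measured. It keeps the core of compound 1 and differs on an amine nitrogen whose other neighbour is a saturated chain carbon, where (3,5-dichlorophenyl)carbamoyl enters: a group of 11 heavy atoms (7 carbon, 1 nitrogen, 1 oxygen, 2 chlorine; one six-membered aromatic ring of carbon only) in place of a group of 10 heavy atoms (7 carbon, 1 nitrogen, 1 sulfur, 1 chlorine; one six-membered aromatic ring of carbon only), on an amine nitrogen. Among the measured compounds shown here, no measured pair isolates this change, so the series offers no direct guide to its size or direction in this assay. The starting point is therefore compound 1 at 17400 nM, and no change beyond the scatter is expected. The estimated 1.1-fold higher number from compound 1 to compound 4 (0.06 log units; within the scatter) is accordingly small. The expected value for compound 4 is 20000 nM, with an estimated range of 8000 nM to 50000 nM.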

Compound 4, half-maximal inhibitory concentration: > 20000 nM
Compound 4: a limit, no number; the forecaster's own chance of this, stated with the estimate: 30%; the middle value lies on the limit itself.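

In this assay compound 4 reads > 20000 nM, which is a limit of the assay and not a number. The change comes to an at least 1.1-fold higher number from compound 1 to compound 4 (0.06 log units; that floor lies within the scatter), so placing (3,5-dichlorophenyl)carbamoyl on an amine nitrogen whose other neighbour is a saturated chain carbon gives only a floor, and that floor does not separate the two compounds. This is the first reading at this position, and the size of the change stays unknown because the reading ends at a limit: the limit of > 20000 nM in this assay, at which 2 of the 4 values shown sit.

The change swaps sulfur for oxygen and adds a second chlorine together, so the compounds shown leave the share of each open. Also open, from the compounds shown here alone, is how a carboxylic acid or an amine in place of (3,5-dichlorophenyl)carbamoyl would read at this position.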